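From 2-methylphenyl to pyridin-3-yl on a shared core

This account rests on a few compounds, and the source may have more. Where it says the series, first, only, none or still open, it means among the compounds named here.

In a functional assay on HCT-15 cells (Homo sapiens) for cytotoxicity, in the presence of a further agent that is not named here (on this read-out higher numbers stand for weaker inhibition and lower numbers for stronger inhibition), compound 1 (`Cc1cccc(-c2cc(-c3ccc(Cl)o3)cc(-c3ccsc3)n2)c1`) gives 21700 nM and compound 2 (`Cc1ccccc1-c1cc(-c2ccc(Cl)o2)cc(-c2ccsc2)n1`) gives 4630 nM as the lower of the two numbers. Compound 3 (`Clc1ccc(-c2cc(-c3cccnc3)nc(-c3ccsc3)c2)o1`) carries pyridin-3-yl in place of 2-methylphenyl on an aromatic carbon. For the measured compounds named here, the one measured step at this carbon, a 4.7-fold lower number from compound 1 to compound 2 (0.67 log units; beyond the scatter) for 2-methylphenyl in place of 3-methylphenyl, is modest, and no pyridin-3-yl compound has been measured. A modest move toward a higher number is therefore expected in this assay, with a 2.2-fold higher number from compound 2 to compound 3 (0.33 log units; beyond the scatter) as the estimated step. Compound 3 is expected at 10000 nM within an estimated range of 3000 nM to 30000 nM in this read-out.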

Compound 3, half-maximal inhibitory concentration: > 50000 nM
Compound 3 gave a limit, no number (the forecaster's own chance of this, stated with the estimate: 10%); middle value at least 5.0-fold (0.69 log units) away from the limit.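

For compound 3, the read-out in this assay ends in a limit and not a number: the limit of > 50000 nM in this assay, at which 1 of the 3 values shown sits.

At this carbon, next to the ring nitrogen, pyridin-3-yl gives an at least 10-fold higher number from compound 2 to compound 3 (1.03 log units; beyond the scatter), and the comparison with the other methylphenyl group gives an at least 2.3-fold higher number from compound 1 to compound 3 (0.36 log units; beyond the scatter). The position therefore responds to exchange of the whole ring as well as to the shift of the methyl seen earlier.

The compounds shown leave open whether the ring nitrogen or the missing methyl accounts for the step. A plain phenyl group at this carbon would separate the two.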